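The source may hold more compounds than are shown below. What is called first, only, known or untested is meant among the compounds shown, and "the series" means these compounds.

Measured compounds:
Compound 1 `O=C1C=CC2(C=C1)OCC(=O)N2S(=O)(=O)c1ccccc1`: > 10000 nM
Compound 2 `N#Cc1cccc(S(=O)(=O)N2C(=O)COC23C=CC(=O)C=C3)c1`: 1910 nM
Compound 3 `O=C1C=CC2(C=C1)OCC(=O)N2S(=O)(=O)c1ccc(OC(F)(F)F)cc1`: 40 nM

In a functional assay on A549 cells (Homo sapiens) for inhibition, read by sulforhodamine B assay, with a stated time of 74 h (on this read-out higher numbers stand for weaker inhibition and lower numbers for stronger inhibition), compound 1 gives > 10000 nM. That value is a limit and not a number, so compound 1 stands at the limit of > 10000 nM in this assay, at which 1 of the 3 values shown sits.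

Compound 4 `O=C1C=CC2(C=C1)OCC(=O)N2S(=O)(=O)c1ccccc1C(F)(F)F` keeps the core of compound 1 and changes it in one place: trifluoromethyl in place of hydrogen on an aromatic carbon. In words, this is trifluoromethyl in place of hydrogen on an aromatic carbon, ortho to a large group.

Two measured steps also replace a hydrogen on an aromatic carbon. The cyano replacement gives an at least 5.2-fold lower number from compound 1 to compound 2 (0.71 log units; beyond the scatter), and the trifluoromethoxy replacement gives an at least 250-fold lower number from compound 1 to compound 3 (2.39 log units; beyond the scatter). Both lie beyond the scatter and both point to stronger inhibition, though the second is much the larger. Neither places its group ortho to a large group, so they guide the direction better than the size.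

A step to a lower number is therefore expected in this assay, probably falling between those two in size. The expected step is an at least 33-fold lower number from compound 1 to compound 4 (1.52 log units; beyond the scatter). For compound 4 the estimated value is 300 nM, with an expected range from 40 nM to 3000 nM.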

Compound 4, half-maximal inhibitory concentration: > 10000 nM
Compound 4: a limit, no number (the forecaster's own chance of this, stated with the estimate: 8%); middle value at least 33-fold (1.52 log units) away from the limit.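

Compound 4, like compound 1, gives a limit and not a number in this assay, so no step can be read between compound 1 and compound 4: the limit of > 10000 nM in this assay, at which 2 of the 4 values shown sit. The compounds shown leave open whether trifluoromethyl in place of hydrogen on an aromatic carbon changes inhibition at all, and by how much.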